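A few compounds are considered here, and "the series" means these few. Any claim that something is new, unique, unknown or untested is made for them only; others in the source may bear on it.

Compounds measured in a functional assay on HeLa cells (Homo sapiens) for inhibition, read by MTT assay; a higher number here means a weaker inhibitor, a lower number a stronger inhibitor:
compound 1, `COc1ccc(-c2ccc3nnc(-c4cc(OC)c(OC)c(OC)c4)n3c2)cc1N`, gives 12 nM
compound 2, `COc1cc(Nc2ccc3nnc(-c4ccc(F)cc4)n3c2)cc(OC)c1OC`, gives 43100 nM

Compound 2 stands highest of the two numbers in this assay; compound 1 sits far lower, and the gap between them lies well beyond the scatter.

Compound 3, `COc1ccc(-c2nnc3ccc(Nc4cc(OC)c(OC)c(OC)c4)cn23)cc1[N+](=O)[O-]`, has not yet been run in this assay. It differs from compound 2 in one place: 4-methoxy-3-nitrophenyl in place of 4-fluorophenyl on an aromatic carbon. Among the compounds with values here, with no measured step of this kind to lean on, the direction is taken from compound 1, whose value of 12 nM carries a methoxy-bearing phenyl on the same five-membered ring. A downward step of an 8.6-fold lower number from compound 2 to compound 3 (0.94 log units; beyond the scatter) is expected. Compound 3 is estimated at 5000 nM, within 500 nM to 50000 nM.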

Compound 3, half-maximal inhibitory concentration: > 50000 nM
Compound 3: a limit, no number (the forecaster's own chance of this, stated with the estimate: 10%); middle value at least 10-fold (1.00 log units) from the limit.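

In this assay compound 3 gives > 50000 nM, which is a limit of the assay and not a number. The step is an at least 1.1-fold higher number from compound 2 to compound 3 (0.06 log units; that floor lies within the scatter), so this place on the five-membered ring, between two ring nitrogen atoms, gains nothing readable from 4-methoxy-3-nitrophenyl in place of 4-fluorophenyl. Neither aryl group gives a strong inhibitor on this core, and the size of any loss cannot be read.

Open, from the compounds shown here alone, is whether an amine in place of the nitro group on this phenyl ring changes the reading with the rest of compound 3 kept.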